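This account rests on a few compounds, and the source may have more. Where it says the series, first, only, none or still open, it means among the compounds named here.

In a functional assay on A-375 cells (Homo sapiens) for antiproliferative activity, read by MTT assay, with a stated time of 24 h, tested at 0.14 ug/mL (a higher number here means a stronger effect of the compound at the concentration tested, a lower number a weaker effect), compound 1 `CCc1ccc2nc(C(=O)Nc3c(F)cc(-c4cccc(F)c4)cc3F)c(C)c(O)c2c1` gives 1.57%, while compound 2 `Cc1c(C(=O)Nc2c(F)cc(-c3cccc(F)c3)cc2F)nc2ccc(F)cc2c1O` gives 0%. Compound 2 holds the lowest of the two numbers, yet the step of a number 1.6 percentage points lower from compound 1 to compound 2 (within the scatter) lies within the scatter, so the two read-outs cannot be ranked. Compound 3 `CCOc1ccc2nc(C(=O)Nc3c(F)cc(-c4cccc(F)c4)cc3F)c(C)c(O)c2c1` differs from compound 2 by ethoxy in place of fluoro on an aromatic carbon. For the measured compounds named here, no measured step exchanges fluoro for ethoxy, and the one step known, a number 1.6 percentage points lower from compound 1 to compound 2 (within the scatter), changed the read-out by less than the scatter. A step of no more than the scatter is therefore expected, a number 3 percentage points higher from compound 2 to compound 3 (within the scatter). Compound 3 is estimated at 3%, between 0% and 15%.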

Compound 3, a percentage reported as inhibition, at one concentration (the size of the read-out at that concentration, not a potency): 1.54%
The estimate for compound 3 lay 1.5 percentage points above the measured number; the measured number falls inside the stated range.
By their numbers in this assay, from the lowest: compounds 2, 3 and 1 (each within the scatter of the next).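

In this assay, putting ethoxy on this aromatic carbon gives a number 1.5 percentage points higher from compound 2 to compound 3 (within the scatter) when it replaces fluoro and a number 0 percentage points lower from compound 1 to compound 3 (within the scatter) when it replaces ethyl. For the compounds shown here, this position has now carried three groups, including one linked through oxygen, and no step between them exceeds the scatter, so the three compounds cannot be ranked. Nothing available gives a reason for this result. Going by these compounds, all three read-outs lie near zero at one concentration, so it remains open whether any group here can raise the effect. An amine or a carboxylic acid at this position would test that.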